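Thiazolyl ketone pyrimidinone series: aryl swap on the pyrimidinone

This account rests on a few compounds, and the source may have more. Where it says the series, first, only, none or still open, it means among the compounds named here.

Two members of the series have been run through a functional assay on U-87MG ATCC cells for antiproliferative activity against U-87 MG (Homo sapiens), read by MTT assay, with a stated time of 48 h, tested at 50 uM; a higher number here means a weaker effect of the compound at the concentration tested, a lower number a stronger effect. Compound 1 `Cc1nc(-c2ccc(Cl)cc2)sc1C(=O)CSc1nc(-c2ccc(Cl)c(Cl)c2)c(C#N)c(=O)[nH]1` gives 93.9% in this assay. Compound 2 `COc1ccc(-c2nc(C)c(C(=O)CSc3nc(-c4ccc(OC)cc4)c(C#N)c(=O)[nH]3)s2)cc1` gives 32.6% in this assay, the lowest of the two numbers, the nearest neighbour being compound 1 at a higher number, a gap beyond the usual scatter.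

The next step leads to compound 3 `COc1ccc(-c2nc(C)c(C(=O)CSc3nc(-c4ccc(Cl)c(Cl)c4)c(C#N)c(=O)[nH]3)s2)cc1`, not yet measured in this assay. It differs from compound 2 at one place only: 3,4-dichlorophenyl in place of 4-methoxyphenyl on an aromatic carbon. Both substituents are of equal heavy-atom count; the incoming one carries no hydrogen-bond acceptor.

Among the measured compounds shown here, no step between measured compounds with a single change is available, so the expected size rests on the two values alone. Compound 1 gives 93.9% in this assay, so the step from compound 2 to compound 3 is expected to run toward the weaker side, estimated as a number 35.4 percentage points higher from compound 2 to compound 3 (beyond the scatter). For compound 3 the expected read-out in this assay is 68%, within a range from 40% to 95%.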

Compound 3, a percentage reported as activity, at one concentration (the size of the read-out at that concentration, not a potency): 78.4%
For compound 3 the middle estimate is 10.4 percentage points below the measured one; the range from low to high includes it.
By their numbers in this assay, from the lowest: compound 2; then compound 3; then compound 1.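

In this assay, putting 3,4-dichlorophenyl in place of 4-methoxyphenyl at this position, on the aromatic carbon ortho to a cyano group, gives a number 45.8 percentage points higher from compound 2 to compound 3 (beyond the scatter) with the heavy-atom count unchanged, so this single place accounts for a large part of the gap between the first two compounds, which could not be assigned to either changed place before. With 3,4-dichlorophenyl held fixed, methoxy in place of chloro on the other aryl group gives a number 15.5 percentage points lower from compound 1 to compound 3 (beyond the scatter), a modest step, so both places affect the read-out and, in this small set, the swap at this position is the larger of the two. Nothing at hand accounts for either step.

The compounds shown leave open whether the two steps add up, which would take 4-methoxyphenyl at this position combined with chloro on the other aryl group. They also leave open how this position responds to a plain phenyl, a 4-aminophenyl or a phenyl carrying a carboxylic acid, and so whether the methoxy or the two chlorines set the size of the step.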